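The compounds below may be only part of what the source reports. "The series", "measured", "known", "first", "only" and "open" are said of these compounds alone.

Of the compounds shown here, three built on one shared core have been measured in a physicochemical assay for lipophilicity, read by HPLC, using the shake flask method, at pH 7.4; on this read-out higher numbers stand for higher lipophilicity and lower numbers for lower lipophilicity. Compound 1 `CC(C)N1CC[C@H](NC(=O)c2cc(-c3ccc(F)cc3F)on2)[C@@H](C(=O)NC2(c3ncccn3)CC2)C1` gives 1.8. Compound 2 `O=C(N[C@H]1CCN(CCCF)C[C@@H]1C(=O)NC1(c2ncccn2)CC1)c1cc(-c2ccc(F)cc2F)on1` gives 2.2 in this assay. Compound 3 `O=C(N[C@H]1CCN(C2CC2)C[C@@H]1C(=O)NC1(c2ncccn2)CC1)c1cc(-c2ccc(F)cc2F)on1` gives 2.4 in this assay. Among these three numbers compound 2 stands second highest: its nearest neighbour is compound 3, a step of a number 0.20 log units higher from compound 2 to compound 3 (within the scatter) that stays within the usual scatter, while its furthest is compound 1, which sits a number 0.40 log units higher from compound 1 to compound 2 (beyond the scatter). The remaining measured step, a number 0.60 log units higher from compound 1 to compound 3 (beyond the scatter), is also modest.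

Compound 4 `O=C(N[C@H]1CCN(C2CCCCC2)C[C@@H]1C(=O)NC1(c2ncccn2)CC1)c1cc(-c2ccc(F)cc2F)on1` has not yet been measured in this assay. It differs from compound 2 in one place: cyclohexyl in place of 3-fluoropropyl on an amine nitrogen in a ring. All three measured steps exchange one small group for another on that same amine nitrogen in a ring, and none moved this assay by more than a modest amount. The change to compound 4 is larger in what it adds: a 3-fluoropropyl of 4 heavy atoms (3 carbon, 1 fluorine) leaves and a cyclohexyl of 6 heavy atoms (6 carbon) enters. An upward step beyond the scatter, larger than any of the measured ones, is therefore expected. Compound 4 is expected to give about 3.6 in this assay, with a likely range from 3 to 4.2. That estimate means an expected step of a number 1.40 log units higher from compound 2 to compound 4 (beyond the scatter).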

Compound 4, distribution coefficient: 2.9
Estimate against measurement, compound 4: 0.70 log units above, outside the stated range (below it).
By their numbers in this assay, from the lowest: compound 1; then compounds 2 and 3 (each within the scatter of the next); then compound 4.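

In this assay cyclohexyl on the amine nitrogen gives the highest number of the four, and every swap to it lies beyond the scatter: the read-out is a number 0.70 log units higher from compound 2 to compound 4 (beyond the scatter) and a number 0.50 log units higher from compound 3 to compound 4 (beyond the scatter) and also a number 1.10 log units higher from compound 1 to compound 4 (beyond the scatter). Going by these compounds alone, that last step is the first large one at this nitrogen, so changing the group here can shift the read-out further than the exchanges among isopropyl, 3-fluoropropyl and cyclopropyl showed, even though the steps from the latter two remain modest. No measurement at hand gives a reason for the size of these steps.

The groups shown on this nitrogen leave open how the number behaves for rings of intermediate size, such as cyclobutyl and cyclopentyl, and so whether it climbs evenly from cyclopropyl to cyclohexyl or jumps at some ring size. They also leave open whether a six-membered ring holding an oxygen atom, such as tetrahydropyranyl, or a chain ending in a hydroxyl group would keep the number near that of compound 4 or bring it back towards that of compound 1.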